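Dropping the carboxy from an indazole-bearing enzyme inhibitor

The source may hold more compounds than are shown below. What is called first, only, known or untested is meant among the compounds shown, and "the series" means these compounds.

Of the compounds shown here, two that share a phenoxyphenoxy-acetone core have been measured in an assay on microsomes from brain for inhibition of Fatty-acid amide hydrolase 1 (Rattus norvegicus), read by fluorescence and HPLC, with a stated time of 45 min; on this read-out higher numbers stand for weaker inhibition and lower numbers for stronger inhibition. Compound 1, with structure `O=C(COc1ccc(Oc2ccccc2)cc1)Cn1ncnn1`, carries a small tetrazole on the core; in this assay compound 1 gives 8 nM. Compound 2, with structure `O=C(COc1ccc(Oc2ccccc2)cc1)Cn1ncc2cc(C(=O)O)ccc21`, carries instead a fused two-ring group with a carboxy on its benzene ring; in this assay compound 2 gives 55 nM. Of these two numbers compound 2 has the higher one, and the gap to compound 1 lies beyond the scatter of repeated measurements. The two structures differ in more than one place, so the gap cannot be assigned to any single change.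

Compound 3, with structure `O=C(COc1ccc(Oc2ccccc2)cc1)Cn1ncc2ccccc21`, keeps the fused group of compound 2 but lacks the acid. The change is hydrogen in place of carboxy on an aromatic carbon. Among the compounds with values here, nothing among the measured compounds isolates this change, so the direction is open; a modest downward move toward the number of compound 1 is expected, as a 2.2-fold lower number from compound 2 to compound 3 (0.34 log units; beyond the scatter). Compound 3 is estimated at 25 nM, with a range from 5 nM to 120 nM.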

Compound 3, half-maximal inhibitory concentration: 2600 nM
Compound 3: the middle estimate sits 100-fold (2.02 log units) below what was measured; the whole stated range lies below it.
By their numbers in this assay, from the lowest: compound 1; then compound 2; then compound 3.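

In this assay, within the data shown here, the carboxy on the fused group proves to matter far more than the earlier compounds could show: putting hydrogen in its place gives a 47-fold higher number from compound 2 to compound 3 (1.67 log units; beyond the scatter) and leaves little of the inhibition seen with compound 2. The fused group without the acid also does poorly against the small tetrazole, since 1H-indazol-1-yl in place of 2H-tetrazol-2-yl on the saturated chain carbon bound to the carbonyl carbon gives a 330-fold higher number from compound 1 to compound 3 (2.51 log units; beyond the scatter) and shows that the group on this chain carbon strongly affects the number. Nothing measured here bears on the reason for either step.

Only hydrogen is shown as a replacement for the carboxy, so it remains open whether an amide, a methyl ester or a nitrile on that aromatic carbon would recover the lost inhibition, or whether only a carboxylic acid does so. Going by these compounds, it is also open whether a carboxy placed elsewhere on the six-membered aromatic ring would give a lower or a higher number than compound 2 does.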